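This account rests on a few compounds, and the source may have more. Where it says the series, first, only, none or still open, it means among the compounds named here.

Measured in a functional assay on PC-6 cells (Homo sapiens) for antiproliferative activity; a lower number here means a stronger inhibitor, a higher number a weaker inhibitor:
compound 1 `CC(C)(C)c1cc2c(N/N=C\c3cccnc3)ncnc2s1`: 1.45 ug/mL
compound 2 `Cc1cccc(/C=N\Nc2ncnc3sc(C(C)(C)C)cc23)n1`: 0.258 ug/mL
compound 3 `CC(C)(C)c1cc2c(N/N=C\c3cccc(CN)n3)ncnc2s1`: 0.036 ug/mL

Compound 3 stands lowest of the three; the steps of a 40-fold lower number from compound 1 to compound 3 (1.61 log units; beyond the scatter) and a 7.2-fold lower number from compound 2 to compound 3 (0.86 log units; beyond the scatter) are both beyond the scatter. Compound 4 `CC(C)(C)c1cc2c(N/N=C\c3cccc(CO)n3)ncnc2s1` differs from compound 3 by hydroxy in place of amino on a saturated chain carbon bound to an aromatic carbon. The step that bears on this is a 7.2-fold lower number from compound 2 to compound 3 (0.86 log units; beyond the scatter), where the amino was added at the same carbon. The hydroxy that enters also carries one hydrogen-bond donor and one acceptor, so part of that gain is expected to remain, and only a modest rise in this assay is expected, a 2.8-fold higher number from compound 3 to compound 4 (0.44 log units; beyond the scatter). For compound 4 the estimate is 0.1 ug/mL, with a range of 0.03 ug/mL to 0.4 ug/mL.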

Compound 4, half-maximal inhibitory concentration: 0.034 ug/mL
Estimate against measurement, compound 4: 2.9-fold (0.47 log units) above; the range from low to high includes it.
By their numbers in this assay, from the lowest: compounds 4 and 3 (each within the scatter of the next); then compound 2; then compound 1.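

In this assay hydroxy in place of amino on this saturated chain carbon gives a 1.1-fold lower number from compound 3 to compound 4 (0.02 log units; within the scatter) and so the two groups cannot be told apart here. The gain at this carbon is not tied to the amino: hydroxy in place of hydrogen gives a 7.6-fold lower number from compound 2 to compound 4 (0.88 log units; beyond the scatter) and the change from pyridin-3-yl to 6-(hydroxymethyl)pyridin-2-yl gives a 43-fold lower number from compound 1 to compound 4 (1.63 log units; beyond the scatter) on the same core. Nothing at hand explains why the two groups match.
Open, on these data alone, is whether methoxy, with no hydroxy hydrogen, or a carboxylic acid would hold the number at this carbon. Also open, as far as these compounds go, is how a longer chain such as 2-hydroxyethyl would read.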